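The source may report more compounds than this note shows. Statements on the series, on what has been measured and on what is new or still open speak of the compounds shown alone.

In an in vitro functional assay on cells for antagonist activity at transient receptor potential cation channel subfamily V member 1 (Homo sapiens), read by reporter gene assay and calcium flux (a lower number here means a stronger inhibitor, a higher number a weaker inhibitor), three compounds have been measured:

compound 1, `O=C(Nc1ccc(Cl)c(C(F)(F)F)c1)Nc1cccc2ccc(C(=O)O)cc12`: 84 nM
compound 2, `Nc1ccc2cccc(NC(=O)Nc3ccc(Cl)c(C(F)(F)F)c3)c2c1`: 34 nM
compound 3, `CS(=O)(=O)Nc1ccc2cccc(NC(=O)Nc3ccc(Cl)c(C(F)(F)F)c3)c2c1`: > 1000 nM

The value given for compound 3 is a limit of this assay, not a number; it stands at the limit of > 1000 nM in this assay, at which 1 of the 3 values shown sits. Compound 3 is therefore the weakest of the three, since its steps to the others are both beyond the scatter: an at least 11-fold higher number from compound 1 to compound 3 (1.07 log units; beyond the scatter) and an at least 29-fold higher number from compound 2 to compound 3 (1.46 log units; beyond the scatter). For comparison, a 2.5-fold lower number from compound 1 to compound 2 (0.39 log units; beyond the scatter).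

Compound 4, `NS(=O)(=O)c1ccc2cccc(NC(=O)Nc3ccc(Cl)c(C(F)(F)F)c3)c2c1`, has not yet been measured. It differs from compound 3 in one place: sulfamoyl in place of methanesulfonamido on an aromatic carbon. Among the measured compounds shown here, no measured step exchanges one sulfur-bearing group for another, so the most relevant evidence is that compound 3, which carries a methanesulfonamido group on the shared core, already lies at the limit, while the carboxy of compound 1 and the amino of compound 2 both give numbers well below it. With a sulfamoyl group entering in place of methanesulfonamido, compound 4 is expected to remain weak, with the step that the limit leaves unreadable from compound 3 to compound 4 estimated as small and uncertain in direction. The estimate for compound 4 in this assay is 1500 nM, with a range of 300 nM to 8000 nM.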

Compound 4, half-maximal inhibitory concentration: 710 nM
The estimate for compound 4 lay 2.1-fold (0.32 log units) above the measured number, within the range that was stated.
By their numbers in this assay, from the lowest: compound 2; then compound 1; then compound 4. At a limit, above all of these: compound 3.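

Compound 3 has no number in this assay, only a limit of the assay: the limit of > 1000 nM in this assay, at which 1 of the 4 values shown sits.

The exchange of methanesulfonamido for sulfamoyl on this aromatic carbon yields a value that can be read, but the step gives only a floor, an at least 1.4-fold lower number from compound 3 to compound 4 (0.14 log units; that floor lies within the scatter), so no order between the two compounds follows from it. Against the amino and carboxy groups at the same place, the sulfamoyl group stands well apart, with a 21-fold higher number from compound 2 to compound 4 (1.32 log units; beyond the scatter) and an 8.5-fold higher number from compound 1 to compound 4 (0.93 log units; beyond the scatter), so both sulfur-bearing groups shown lie on the weak side of those two groups, which the single limit of the methanesulfonamido group could not show with a measured number.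

On these data alone, the true size of the change from methanesulfonamido to sulfamoyl remains open, as only one side of it has a number. Also open, as far as these compounds go, is how a carboxamide, an acetamido group or a methylsulfonyl group attached directly to this aromatic carbon would compare, and whether the gap between the amino and sulfamoyl groups would narrow with any of them.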